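A few compounds are considered here, and "the series" means these few. Any claim that something is new, unique, unknown or untested is made for them only; others in the source may bear on it.

Of the compounds shown here, two have been measured in a functional assay on MDA-MB-231 cells (Homo sapiens) for inhibition, read by MTT assay, with a stated time of 72 h; a higher number here means a weaker inhibitor, a lower number a stronger inhibitor. Compound 1 `O=C(CSc1nc(Nc2ccccc2)c2ccccc2n1)Nc1ccc(Br)cc1` gives 11500 nM. Compound 2 `C=CC(=O)Nc1cccc(NC(=O)CSc2nc(Nc3ccccc3F)c3ccccc3n2)c1` gives 18700 nM, the higher of the two numbers, yet the gap to compound 1 lies within the scatter, so the two cannot be told apart on these data. Compound 3 `C=CC(=O)Nc1cccc(NC(=O)CSc2nc(Nc3ccc(CC)cc3)c3ccccc3n2)c1` has not been measured. It differs from compound 2 in one place: 4-ethylphenyl in place of 2-fluorophenyl on a nitrogen on an aromatic ring. Among the compounds with values here, no measured pair shows this particular change, so its effect is unknown here. Because compound 1 at 11500 nM and compound 2 at 18700 nM sit within the scatter of each other although they differ in more than one place, only a small step is expected from this single change. The step of a 1.3-fold lower number from compound 2 to compound 3 (0.13 log units; within the scatter) is the expected one, and it does not exceed the scatter. Compound 3 is expected to give about 14000 nM, with a likely range from 5000 nM to 40000 nM.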

Compound 3, half-maximal inhibitory concentration: 14400 nM
For compound 3 the middle estimate is 1.0-fold (0.01 log units) below the measured one; the range from low to high includes it.
By their numbers in this assay, from the lowest: compounds 1, 3 and 2 (each within the scatter of the next).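

In this assay, within the data shown here, this is the first comparison in the set where only one place differs, and it gives a 1.3-fold lower number from compound 2 to compound 3 (0.11 log units; within the scatter). At this place, on a nitrogen on an aromatic ring, 2-fluorophenyl and 4-ethylphenyl therefore cannot be told apart, even though the two groups differ in both the substituent and where it sits on the ring. No measured property is available to account for this result.

Among these compounds, the single step cannot separate the swap of fluorine for ethyl from the shift in where the substituent sits, so either could matter on its own and the two could offset each other. Going by these compounds, it also remains open whether a carboxylic acid or an amine on this phenyl ring, or a chain longer than ethyl, would give a step beyond the scatter.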